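This account rests on a few compounds, and the source may have more. Where it says the series, first, only, none or still open, it means among the compounds named here.

In an ADME assay on the whole organism (Mus musculus, strain CD-1) for pharmacokinetics (a higher number here means faster removal of the compound, a lower number slower removal), compound 1 `COc1cc([C@](O)(CCN(C)C)[C@@H](c2cc3cc(C#N)ccc3nc2OC)c2cccc(C)c2F)cc(OC(F)F)n1` gives 13 mL/min/kg. Compound 2 `COc1cc([C@](O)(CCN(C)C)[C@@H](c2cc3cc(C#N)ccc3nc2OC)c2ccnc(OC)c2OC)cc(OC(F)F)n1` gives 24 mL/min/kg, and compound 3 `COc1cc([C@](O)(CCN(C)C)[C@@H](c2cc3cc(C#N)ccc3nc2OC)c2cccc(OC)c2F)cc(SC)n1` gives 42 mL/min/kg, so compound 1 sits clearly below compound 3 only. Moving to compound 4 `CCSc1cc([C@](O)(CCN(C)C)[C@@H](c2cc3cc(C#N)ccc3nc2OC)c2cccc(C)c2F)cc(SCC)n1` makes one change: a group of 12 heavy atoms (9 carbon, 1 nitrogen, 2 sulfur; one six-membered aromatic ring with 1 hetero atom) in place of a group of 12 heavy atoms (7 carbon, 1 nitrogen, 2 oxygen, 2 fluorine; one six-membered aromatic ring with 1 hetero atom), on a saturated chain carbon bound to an oxygen on a saturated carbon and two saturated chain carbons. Among the measured compounds shown here, the only measured single change, a 1.8-fold higher number from compound 1 to compound 2 (0.27 log units; within the scatter), concerns a different group and says little here. For the measured compounds named here, the closer hint is compound 3, the one measured compound with sulfur in that group, at 42 mL/min/kg, although it also differs from compound 1 elsewhere. A rise in this assay beyond the scatter is therefore expected, and the expected size is a 3.1-fold higher number from compound 1 to compound 4 (0.49 log units; beyond the scatter). For compound 4 the estimated value is 40 mL/min/kg, with an expected range of 18 mL/min/kg to 85 mL/min/kg.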

Compound 4, clearance: 9.4 mL/min/kg
Beside the measured number, compound 4's estimate is 4.3-fold (0.63 log units) above it, and the stated range ends above it.
By their numbers in this assay, from the lowest: compounds 4, 1, 2 and 3 (each within the scatter of the next, the first and the last beyond it).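

In this assay, the group with two sulfur atoms in place of the group with two oxygen and two fluorine atoms gives a 1.4-fold lower number from compound 1 to compound 4 (0.14 log units; within the scatter), so compound 1 and compound 4 cannot be told apart. At this position, then, an exchange of the whole group, with sulfur entering, need not shift the number beyond the scatter. Nothing shown explains this result. Still open, as far as these compounds go, is how a group carrying an amine or a carboxylic acid would behave on this same carbon. Also open, from the compounds shown here alone, is whether this result holds with other groups elsewhere on the shared core.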